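A few compounds are considered here, and "the series" means these few. Any claim that something is new, unique, unknown or untested is made for them only; others in the source may bear on it.

Measured compounds in a functional assay on CHO-K1 cells for agonist activity at Glucose-dependent insulinotropic receptor (Homo sapiens), read by cAMP accumulation and immunoassay, with a stated time of 1 h; on this read-out lower numbers stand for an effect already at smaller amounts and higher numbers for an effect only at larger amounts of compound:
- compound 1, `Cc1c(Oc2ccc(/C=C3\SC(=O)NC3=O)cc2)ncnc1OC1CCN(C(=O)OCC(C)C)CC1`: 75.1 nM
- compound 2, `Cc1c(Oc2ccc(/C=C3\SC(=O)NC3=O)cc2)ncnc1OC1CCN(C(=O)OCc2ccccc2)CC1`: 805 nM
- compound 3, `CC(C)COC(=O)N1CCC(Oc2cc(Oc3ccc(/C=C4\SC(=O)NC4=O)cc3)ncn2)CC1`: 745 nM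

For the measured compounds named here, the one change that recurs is phenyl in place of isopropyl on a saturated chain carbon bound to an oxygen next to a carbonyl group. Between the two measured compounds this change produced a large step, an 11-fold higher number from compound 1 to compound 2 (1.03 log units; beyond the scatter). Compound 3 carries a different core; the two cores differ by hydrogen in place of methyl on an aromatic carbon, a change that by itself gave a 9.9-fold higher number from compound 1 to compound 3 (1.00 log units; beyond the scatter). Compound 2 and compound 3 give numbers within the scatter of each other, so no order can be read between them.

Compound 4, `O=C1NC(=O)/C(=C/c2ccc(Oc3cc(OC4CCN(C(=O)OCc5ccccc5)CC4)ncn3)cc2)S1`, has not been measured in this assay. It carries the same change as compound 2, (phenyl in place of isopropyl on a saturated chain carbon bound to an oxygen next to a carbonyl group), but on the core of compound 3. The expectation for compound 4 rests on the step of an 11-fold higher number from compound 1 to compound 2 (1.03 log units; beyond the scatter): the same change on the other core is expected to give a step of about an 8.1-fold higher number from compound 3 to compound 4 (0.91 log units; beyond the scatter), roughly the earlier size, with a wider range because only one earlier case exists. The value of compound 4 in this assay is therefore estimated at 6000 nM.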

Compound 4, half-maximal effective concentration: 107 nM
Beside the measured number, compound 4's estimate is 56-fold (1.75 log units) above it, and the stated range ends above it.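

On the core of compound 3, phenyl in place of isopropyl gives a 7.0-fold lower number from compound 3 to compound 4 (0.84 log units; beyond the scatter), a step opposite in direction to the one on the core of compound 1 in this assay: the same change on two cores in this assay, an 11-fold higher number (1.03 log units; beyond the scatter) from compound 1 to compound 2 and a 7.0-fold lower number (0.84 log units; beyond the scatter) from compound 3 to compound 4, 75-fold (1.87 log units) apart, beyond the scatter of two such steps

Read the other way, hydrogen in place of methyl on an aromatic carbon gives a 7.5-fold lower number from compound 2 to compound 4 (0.88 log units; beyond the scatter) with the benzyloxycarbonyl group, again opposite to the step with the isobutoxycarbonyl group: the same change on two cores in this assay, a 9.9-fold higher number (1.00 log units; beyond the scatter) from compound 1 to compound 3 and a 7.5-fold lower number (0.88 log units; beyond the scatter) from compound 2 to compound 4, 75-fold (1.87 log units) apart, beyond the scatter of two such steps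

For the compounds shown here, the two changes therefore do not add up in these compounds, and a step measured on one core gave neither the size nor the direction of the step on the other; with only two cores and two groups, this does not show why the direction reverses or how far the reversal extends.

Open, on these data alone, is whether the reversal belongs to phenyl itself or also appears with a cyclohexyl ring or a longer chain such as pentyl at this place. Also open, as far as these compounds go, is whether ethyl or chlorine on the aromatic carbon would behave like the methyl of compound 1 or the hydrogen of compound 3.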